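The compounds below may be only part of what the source reports. "The series", "measured", "known", "first", "only" and "open" are said of these compounds alone.

Measured in an ADME assay on LLC-MK2 cells (Macaca mulatta) for cytotoxicity, read by spectrophotometry and crystal violet staining, with a stated time of 4 days; a lower number here means that less compound is tolerated, a higher number that more compound is tolerated:
- compound 1 `CC(C)n1ncc2c(C(=O)Nc3ccc(F)cc3)cc(-c3cccs3)nc21`: > 200000 nM (a limit)
- compound 2 `CC(C)n1ncc2c(C(=O)Nc3c(F)cccc3F)cc(-c3cccs3)nc21`: > 200000 nM (a limit)
- compound 3 `CC(C)n1ncc2c(C(=O)Nc3cncnc3)cc(-c3cccs3)nc21`: 20000 nM

Compound 1 stands at the limit of > 200000 nM in this assay, at which 2 of the 3 values shown sit. This entry for compound 1 is a limit and not a number.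

Compound 4 `CC(C)n1ncc2c(C(=O)Nc3ccc(F)cc3)cc(-c3ccco3)nc21` is compound 1 with a single change: furan-2-yl in place of thiophen-2-yl on an aromatic carbon. Furan-2-yl takes the place of thiophen-2-yl on an aromatic carbon, next to the ring nitrogen, and the rest of the molecule stays the same.

Among the compounds with values here, no measured step touches this place. All three measured steps swap the group on the amide-type nitrogen instead, so they bear on compound 4 only indirectly. Putting 2,6-difluorophenyl in place of 4-fluorophenyl gave a step that the two limits leave unreadable from compound 1 to compound 2. Both readable steps came with pyrimidin-5-yl, namely an at least 10-fold lower number from compound 1 to compound 3 (1.00 log units; beyond the scatter) and an at least 10-fold lower number from compound 2 to compound 3 (1.00 log units; beyond the scatter). That group is absent from compound 4, which keeps 4-fluorophenyl, so no step beyond the scatter is expected in this assay.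

The estimated step is a number no higher from compound 1 to compound 4 (the limit leaves the size open). Compound 4 may well report only a limit again. As a number, the expected value for compound 4 is 200000 nM. The estimated range for compound 4 runs from 70000 nM to 400000 nM.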

Compound 4, half-maximal cytotoxic concentration: > 200000 nM
Compound 4: only a limit was reported; the forecaster's own chance of this, stated with the estimate: 60%; the middle value sits exactly at the limit.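

In this assay compound 4 gives > 200000 nM, which is a limit and not a number. Compound 1 also reports only a limit, so no step from compound 1 to compound 4 can be read: the limit of > 200000 nM in this assay, at which 3 of the 4 values shown sit.

The compounds shown leave open whether furan-2-yl and thiophen-2-yl differ at all in this assay.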